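Series notes: the step from compound 3 to compound 4

The source may hold more compounds than are shown below. What is called first, only, known or untested is meant among the compounds shown, and "the series" means these compounds.

Measured so far, with inhibition in a functional assay on the whole organism (strain Kunming) for inhibition, with Mus musculus as the target, with a stated time of 1 h, at a dose of 40 mg/kg by the oral route; a higher number here means more inhibition at the dose given (going by the name of the read-out), a lower number less inhibition:
compound 1, `O=C(/C=C/c1ccccc1)c1ccc(N2CCN(c3ccc(Cl)c(Cl)c3)CC2)cc1`: 13.4%
compound 2, `O=C(/C=C/c1ccccc1)c1ccc(N2CCN(c3ccc([N+](=O)[O-])cc3)CC2)cc1`: 55.4%
compound 3, `O=C(/C=C/c1ccc(Cl)cc1)c1ccc(N2CCN(S(=O)(=O)c3ccc(Cl)cc3)CC2)cc1`: 56.6%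

Compound 3 gives the highest of the three numbers in this assay. Its nearest neighbour is compound 2, whose value lies within the scatter of compound 3, so no order between these two can be claimed. The furthest is compound 1, which lies beyond the scatter below compound 3.

Within the data shown here, only one single-place step is available: a number 42 percentage points higher from compound 1 to compound 2 (beyond the scatter). That step changes the group on the amine nitrogen in the ring and says nothing about the other aryl ring.

Compound 4, `O=C(/C=C/c1ccccc1)c1ccc(N2CCN(S(=O)(=O)c3ccc(Cl)cc3)CC2)cc1`, is the next compound to be measured. It differs from compound 3 as follows: hydrogen in place of chloro on an aromatic carbon. Among the measured compounds shown here, no measured step touches this position, so there is no direct precedent for the change. With the shared core and the substituted sulfonyl group held constant, the expectation is a step of no size beyond the scatter: a number 6.6 percentage points lower from compound 3 to compound 4 (within the scatter). Compound 4 is therefore estimated at 50% in this assay, with a range from 30% to 70%.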

Compound 4, a percentage reported as inhibition, in the whole organism at one dose (the size of the read-out at that dose, not a potency): 46.8%
Estimate against measurement, compound 4: 3.2 percentage points above, within the range that was stated.
By their numbers in this assay, from the lowest: compound 1; then compounds 4, 2 and 3 (each within the scatter of the next).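

In this assay, among these compounds, hydrogen in place of chloro on the aromatic carbon para to a large group gives a number 9.8 percentage points lower from compound 3 to compound 4 (within the scatter) and so gives the first reading at this position: going from 2-(4-chlorophenyl)ethenyl to 2-phenylethenyl produces no step that can be told from the scatter. With the 2-phenylethenyl side now shared, the group on the ring nitrogen can be compared directly: (4-chlorophenyl)sulfonyl in place of 4-nitrophenyl gives a number 8.6 percentage points lower from compound 2 to compound 4 (within the scatter) and cannot be separated from it, while (4-chlorophenyl)sulfonyl in place of 3,4-dichlorophenyl gives a number 33.4 percentage points higher from compound 1 to compound 4 (beyond the scatter) and is a large step, so two different groups on that nitrogen now stand clear of the 3,4-dichlorophenyl compound, alongside a number 42 percentage points higher from compound 1 to compound 2 (beyond the scatter) as the earlier step. Nothing available offers a reason for any of these steps.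

The compounds shown leave open whether a methoxy group or an amine on this aromatic carbon would also stay within the scatter of chloro and hydrogen. Also open, going by these compounds, is whether the chloro on the sulfonyl side matters at all, which a plain benzenesulfonyl or a methylsulfonyl group on the ring nitrogen would address.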